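Replacing 2,5-dimethoxyphenyl with cyclohexyl

The source may hold more compounds than are shown below. What is called first, only, known or untested is meant among the compounds shown, and "the series" means these compounds.

Measured in a functional assay on A549 cells (Homo sapiens) for inhibition, read by MTT assay, with a stated time of 48 h; a higher number here means a weaker inhibitor, a lower number a stronger inhibitor:
- compound 1 `Brc1ccc2[nH]cc(C(c3ccccc3)c3c[nH]c4ccc(Br)cc34)c2c1` gives 7500 nM
- compound 2 `Oc1cccc(C(c2c[nH]c3ccc(Br)cc23)c2c[nH]c3ccc(Br)cc23)c1` gives 8000 nM
- compound 3 `COc1ccc(OC)c(C(c2c[nH]c3ccc(Br)cc23)c2c[nH]c3ccc(Br)cc23)c1` gives 10000 nM

On these numbers, compound 3 stands level with the other two, since a 1.3-fold higher number from compound 1 to compound 3 (0.12 log units; within the scatter) and a 1.3-fold higher number from compound 2 to compound 3 (0.10 log units; within the scatter) both lie within the usual scatter. Compound 4 `Brc1ccc2[nH]cc(C(c3c[nH]c4ccc(Br)cc34)C3CCCCC3)c2c1` has not yet been measured. Its structure differs from that of compound 3 by cyclohexyl in place of 2,5-dimethoxyphenyl on a saturated chain carbon bound to two aromatic carbons.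

Among the compounds with values here, three measured steps bear on this change, as each alters the group on that same carbon. Besides the two above, there is a 1.1-fold higher number from compound 1 to compound 2 (0.03 log units; within the scatter). All three are small, so the group on that carbon has so far made no visible difference in this assay. However, none of the measured compounds carries a non-aromatic ring there, which leaves the estimate uncertain. No step beyond the scatter is expected, and the expected step is a 1.2-fold lower number from compound 3 to compound 4 (0.07 log units; within the scatter). Compound 4 is estimated at 8500 nM, with an expected range of 4000 nM to 18000 nM.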

Compound 4, half-maximal inhibitory concentration: 5500 nM
For compound 4 the middle estimate is 1.5-fold (0.19 log units) above the measured one, and the stated range covers the measured number.
By their numbers in this assay, from the lowest: compounds 4, 1, 2 and 3 (each within the scatter of the next).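

Within the data shown here, compound 4 is the first here to carry a non-aromatic ring on the saturated chain carbon bound to two aromatic carbons, and in this assay cyclohexyl stands level with all three aromatic groups (a 1.8-fold lower number from compound 3 to compound 4 (0.26 log units; within the scatter); a 1.5-fold lower number from compound 2 to compound 4 (0.16 log units; within the scatter); a 1.4-fold lower number from compound 1 to compound 4 (0.13 log units; within the scatter)). The earlier compounds shown here all carry an aromatic ring at this position, so they could not show that the aromatic ring can be exchanged for a saturated one, without any oxygen, and the number stay within the scatter. No measurement shown accounts for why these groups read alike.

As far as these compounds go, all four compounds still carry a six-membered ring on this carbon, so a group of another shape remains untested. An amine, a carboxylic acid or a longer chain at this position could give a different reading, or could leave the number where it stands.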